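This account rests on a few compounds, and the source may have more. Where it says the series, first, only, none or still open, it means among the compounds named here.

Measured so far:
compound 1, `FC(F)(F)c1c(-c2ccc(OC3CCOCC3)c(Cl)c2)ccn2c(CC3CC3)nnc12`, 89.1 nM in an assay on cells for positive allosteric modulation of metabotropic glutamate receptor 2 (Homo sapiens), with stated times of 20 min, 15 s and 40 min, in the presence of a further agent that is not named here; on this read-out higher numbers stand for an effect only at larger amounts of compound and lower numbers for an effect already at smaller amounts;
compound 2, `FC(F)(F)c1c(-c2ccc(NC3CCOCC3)c(Cl)c2)ccn2c(CC3CC3)nnc12`, 18.6 nM.

Among the measured compounds shown here, compound 2 gives the lowest of the two numbers; its nearest neighbour is compound 1, and the one step measured, a 4.8-fold lower number from compound 1 to compound 2 (0.68 log units; beyond the scatter), concerns the swap of oxygen for nitrogen. Compound 3, `O[C@]1(C2CC2)CC[C@H](Nc2ccc(-c3ccn4c(CC5CC5)nnc4c3C(F)(F)F)cc2Cl)CC1`, differs from compound 2 by 4-cyclopropyl-4-hydroxycyclohexyl in place of oxan-4-yl on a nitrogen on an aromatic ring. No measured step touches a change of this kind, so nothing shown bears on it directly. Compound 3 is therefore expected to stay close to compound 2, with an estimated step of a 1.2-fold lower number from compound 2 to compound 3 (0.09 log units; within the scatter), and its value in this assay is estimated at 15 nM, between 5 nM and 50 nM.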

Compound 3, half-maximal effective concentration: 11.2 nM
The estimate for compound 3 lay 1.3-fold (0.13 log units) above the measured number, within the range that was stated.
By their numbers in this assay, from the lowest: compounds 3 and 2 (each within the scatter of the next); then compound 1.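

Compound 3 shows that, on the nitrogen on an aromatic ring, the oxan-4-yl can give way to the larger 4-cyclopropyl-4-hydroxycyclohexyl, which carries a hydrogen-bond donor, with no shift beyond the scatter in this assay (a 1.7-fold lower number from compound 2 to compound 3 (0.22 log units; within the scatter)). Measured against the oxygen-linked compound 1, the gain stays beyond the scatter (an 8.0-fold lower number from compound 1 to compound 3 (0.90 log units; beyond the scatter)). Nothing available explains these results.

The compounds shown leave open whether the hydroxy group or the cyclopropyl carries any weight, since neither appears alone. An amine in place of the hydroxy group, or a methyl in place of the cyclopropyl, would address this.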